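The compounds below may be only part of what the source reports. "The series", "measured", "known", "first", "only" and "open" are said of these compounds alone.

Measured in a functional assay on SK-OV-3 cells (Homo sapiens) for inhibition, read by MTT assay, with a stated time of 24 h; a lower number here means a stronger inhibitor, a higher number a weaker inhibitor:
Compound 1 `C/C=C(\C)C(=O)O[C@@H]1C(=O)/C=C2/C3=CC(=O)O[C@@H](c4ccoc4)[C@]3(C)CC[C@@H]2[C@@]2(C)C(=O)C[C@]1(C)[C@@H]2[C@@H](O)C(=O)OC`: > 100000 nM
Compound 2 `C/C=C(\C)C(=O)O[C@H]1[C@]2(C)C[C@@H]3O[C@@]1(O)C=C1C4=CC(=O)O[C@@H](c5ccoc5)[C@]4(C)CC[C@@H]1[C@]3(C)[C@@H]2C(=O)C(=O)OC`: > 100000 nM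
Compound 3 `C/C=C(\C)C(=O)O[C@@H]1[C@]2(OC(=O)CCCC)C=C3C4=CC(=O)O[C@@H](c5ccoc5)[C@]4(C)CC[C@@H]3[C@@]3(C)[C@H](C[C@]1(C)[C@H]3[C@@H](OC(=O)CCCC)C(=O)OC)O2`: > 100000 nM

Compound 3 gives > 100000 nM, which is a limit and not a number. It shares that position with the other two compounds: the limit of > 100000 nM in this assay, at which 3 of the 3 values shown sit. Compound 4 `C/C=C(\C)C(=O)O[C@@H]1[C@]2(OC(=O)CCCC)C=C3C4=CC(=O)O[C@@H](c5ccoc5)[C@]4(C)CC[C@@H]3[C@@]3(C)[C@H](C[C@]1(C)[C@H]3[C@@H](O)C(=O)OC)O2` differs from compound 3 as follows: hydrogen in place of butylcarbonyl on an oxygen on a saturated carbon. Hydrogen replaces butylcarbonyl on an oxygen on a saturated carbon, so (butylcarbonyl)oxy becomes hydroxy. Compound 1 also carries hydroxy(methoxycarbonyl)methyl and gives > 100000 nM, again a limit. No step beyond the scatter is therefore expected in this assay, in either direction. The estimated change is a number no higher from compound 3 to compound 4 (the limit leaves the size open). For compound 4 the expected value is 100000 nM, with an estimated range of 40000 nM to 200000 nM.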

Compound 4, half-maximal inhibitory concentration: 13700 nM
Compound 4: middle estimate off by 7.3-fold (0.86 log units), on the high side; the whole stated range lies above it.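

In this assay, hydroxy in place of (butylcarbonyl)oxy on the saturated carbon gives an at least 7.2-fold lower number from compound 3 to compound 4 (0.86 log units; beyond the scatter). The butylcarbonyl on this oxygen therefore decides whether the shared core reaches a measurable value in this cell assay. Compound 4 is the only compound shown with a number rather than a limit: the limit of > 100000 nM in this assay, at which 3 of the 4 values shown sit.

From the compounds shown here alone, compound 3 stands at a limit, so the full size of the step stays open. The compounds shown also leave open how an acetyl group or a methyl ether on this oxygen would compare with hydroxy.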